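Replacing a substituted anilino group with a fluoropyridinyl group

The source may report more compounds than this note shows. Statements on the series, on what has been measured and on what is new or still open speak of the compounds shown alone.

Measured so far:
- compound 1, `CCS(=O)(=O)Nc1cc(-c2ccc3ncnc(Nc4ccc(OC(F)(F)F)cc4)c3c2)cnc1OC`: 23700 nM
- compound 2, `CCS(=O)(=O)Nc1cc(-c2ccc3ncnc(Nc4ccc(OC)c(OC)c4)c3c2)cnc1OC`: 2430 nM
- compound 3, `CCS(=O)(=O)Nc1cc(-c2ccc3ncnc(Nc4ccc(OC)c(Cl)c4)c3c2)cnc1OC`: 3320 nM

All three share one core and differ only in the aromatic group carried on the nitrogen attached to that core. In a functional assay on MCF7 cells (Homo sapiens) for cytotoxicity, read by sulforhodamine B assay, with a stated time of 72 h (a higher number here means a weaker inhibitor, a lower number a stronger inhibitor), compound 3 gives 3320 nM, the second highest of the three numbers. Its nearest neighbour is compound 2: a 1.4-fold higher number from compound 2 to compound 3 (0.14 log units; within the scatter). Compound 1 stands furthest away: a 7.1-fold lower number from compound 1 to compound 3 (0.85 log units; beyond the scatter), and the related step of a 9.8-fold lower number from compound 1 to compound 2 (0.99 log units; beyond the scatter) points the same way.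

Compound 4, `CCS(=O)(=O)Nc1cc(-c2ccc3ncnc(Nc4ccc(F)nc4)c3c2)cnc1OC`, is the next compound to be measured. It differs from compound 3 in one place: 6-fluoropyridin-3-yl in place of 3-chloro-4-methoxyphenyl on a nitrogen on an aromatic ring. Going by the values given here, none of the measured steps exchanges a ring of carbon only for one with a hetero atom, so the measured steps bear on this change only loosely. They do show that the group at this position can move the number by a modest amount in either direction. With both the chloro and the methoxy gone, a weaker result is expected, so the estimate is a 2.4-fold higher number from compound 3 to compound 4 (0.38 log units; beyond the scatter). Compound 4 is therefore expected to give 8000 nM, within a range from 2000 nM to 30000 nM.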

Compound 4, half-maximal inhibitory concentration: 5390 nM
Estimate against measurement, compound 4: 1.5-fold (0.17 log units) above, and the stated range covers the measured number.
By their numbers in this assay, from the lowest: compounds 2, 3 and 4 (each within the scatter of the next, the first and the last beyond it); then compound 1.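

In this assay, swapping the 3-chloro-4-methoxyphenyl group for a ring with a hetero atom gives a 1.6-fold higher number from compound 3 to compound 4 (0.21 log units; within the scatter), so this change leaves the number within the usual scatter. Compared with the other two groups, 6-fluoropyridin-3-yl gives a 2.2-fold higher number from compound 2 to compound 4 (0.35 log units; beyond the scatter) and a 4.4-fold lower number from compound 1 to compound 4 (0.64 log units; beyond the scatter), which shows that neither chloro nor methoxy is needed for a number well clear of that of compound 1. No measurement shown here explains these differences.

Compound 4 differs from compound 3 in both the ring and its substituents, so the part played by the ring nitrogen cannot be separated from that of the fluorine. A 4-fluorophenyl group and an unsubstituted pyridin-3-yl group on the same nitrogen would be the comparisons that could tell these parts apart.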